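The compounds below may be only part of what the source reports. "The series", "measured", "known", "first", "only" and "open" are said of these compounds alone.

Measured compounds:
- compound 1, `COc1ccc(-n2cnc3cnc(Nc4cccc(NS(C)(=O)=O)c4)cc32)cc1OC`: 0.58
- compound 2, `COc1ccc(-n2cnc3cnc(Oc4cccc(NC(C)=O)c4)cc32)cc1OC`: 0.19
- compound 3, `COc1ccc(-n2cnc3cnc(-c4cccc(NC(C)=O)c4)cc32)cc1OC`: 0.21

In an ADME assay on S9 fraction from liver (Mus musculus) for metabolic stability, read by LC-MS, using NADPH, with a stated time of 45 min, tested at 3 uM, in the presence of a further agent that is not named here (a lower number here means that the liver removes a smaller share, a higher number that the liver removes a larger share of the compound in one pass), compound 3 gives 0.21, the second highest of the three numbers. Its nearest neighbour is compound 2, whose 0.19 lies within the usual scatter of it, so the two cannot be ordered. Compound 1, with 0.58, sits furthest away, and that gap is beyond the scatter, so compound 1 is removed to a larger share than compound 3 in this assay.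

Compound 4, `COc1ccc(-n2cnc3cnc(-c4ccccc4)cc32)cc1OC`, has not been run in this assay. Relative to compound 3 the change is hydrogen in place of acetamido on an aromatic carbon, on an aromatic carbon of a six-membered aromatic ring of carbon only, meta to a large group. Within the data shown here, no measured pair shares this change, so there is no step to lean on. The two lower numbers of the series, compound 2 and compound 3, both carry the acetamido group; nothing here shows what its loss does.

The expectation is a step a number 0.060 higher from compound 3 to compound 4 (within the scatter) that stays within or only just beyond the scatter. Compound 4 is estimated at 0.27, with a range from 0.12 to 0.5.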

Compound 4, hepatic extraction ratio: 1
For compound 4 the middle estimate is 0.73 below the measured one; measured number above the stated range.
By their numbers in this assay, from the lowest: compounds 2 and 3 (each within the scatter of the next); then compound 1; then compound 4.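

In this assay, among these compounds, this aromatic carbon of the six-membered ring is not indifferent to what it carries: hydrogen in place of acetamido gives a number 0.79 higher from compound 3 to compound 4 (beyond the scatter), the first step that can be read for a change in one place. Every earlier compound holds a group at this place, so only now is there a reading for the ring without one, and with the rest of compound 3 unchanged, the step belongs to this single change. What lies behind the step remains unexplained, as no supporting measurement bears on it.

Going by these compounds, it remains open whether the step is specific to acetamido or whether any group at this place would give a similar number; an amine, a carboxylic acid, a methoxy group or an amide with a longer chain would help separate those two readings. On these data alone, it also remains open whether hydrogen in place of acetamido gives a step of similar size in the setting of compound 2, which differs from compound 3 in how this ring is joined to the core.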